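A few compounds are considered here, and "the series" means these few. Any claim that something is new, unique, unknown or untested is made for them only; others in the source may bear on it.

Of the compounds shown here, three built on one shared core have been tested in a functional assay on MDA-MB-231 cells (Homo sapiens) for cytotoxicity, read by MTT assay, with a stated time of 72 h; a lower number here means a stronger inhibitor, a higher number a weaker inhibitor. Compound 1 `CCN(CC)Cc1ccc2nc(NC(=O)N/N=C/c3cn(Cc4cccc(Cl)c4)c4ccccc34)sc2c1` gives 2050 nM, compound 2 `CN(C)Cc1ccc2nc(NC(=O)N/N=C/c3cn(Cc4ccc(Cl)cc4)c4ccccc34)sc2c1` gives 880 nM, and compound 3 `CC1CCN(Cc2ccc3nc(NC(=O)N/N=C/c4cn(Cc5ccc(Cl)cc5)c5ccccc45)sc3c2)CC1` gives 2850 nM. Compound 3 carries the highest of the three numbers; its gap to compound 1 lies within the scatter, while the step of a 3.2-fold higher number from compound 2 to compound 3 (0.51 log units; beyond the scatter) lies beyond it. Compound 4 `CCN(CC)Cc1ccc2nc(NC(=O)N/N=C/c3cn(Cc4ccc(Cl)cc4)c4ccccc34)sc2c1` differs from compound 3 by diethylamino in place of 4-methylpiperidin-1-yl on a saturated chain carbon bound to an aromatic carbon. For the measured compounds named here, the one step that bears on this exchange put 4-methylpiperidin-1-yl in place of dimethylamino at the same place and raised the number; the present change runs the other way, toward a small open-chain amine, so a lower number is expected. Compound 1 also carries diethylamino but differs elsewhere as well, so it only hints. The expected step is a 2.6-fold lower number from compound 3 to compound 4 (0.41 log units; beyond the scatter). Compound 4 is estimated at 1100 nM, within 500 nM to 2600 nM.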

Compound 4, half-maximal inhibitory concentration: 2570 nM
Estimate against measurement, compound 4: 2.3-fold (0.37 log units) below, and the stated range covers the measured number.
By their numbers in this assay, from the lowest: compound 2; then compounds 1, 4 and 3 (each within the scatter of the next).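

In this assay, diethylamino and 4-methylpiperidin-1-yl cannot be told apart at this place, on a saturated chain carbon bound to an aromatic carbon (a 1.1-fold lower number from compound 3 to compound 4 (0.04 log units; within the scatter)). Open chain or ring therefore makes no readable difference here, yet dimethylamino stands apart from diethylamino (a 2.9-fold higher number from compound 2 to compound 4 (0.47 log units; beyond the scatter)). 4-Chlorophenyl in place of 3-chlorophenyl also gives no readable difference with diethylamino in place (a 1.3-fold higher number from compound 1 to compound 4 (0.10 log units; within the scatter)).

As far as these compounds go, whether an unsubstituted primary amine or a morpholine ring at this place would fall nearer compound 2 or compound 4 remains open. No measurement shown here explains these steps.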